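The source may report more compounds than this note shows. Statements on the series, on what has been measured and on what is new or still open speak of the compounds shown alone.

Compound 1 `C[C@]1(c2ccc(F)cc2)CN(C(=O)NCc2ccncc2)C[C@H]1c1ccc(C(O)(C(F)(F)F)C(F)(F)F)cc1`: 1%
Compound 2 `C[C@]1(c2ccc(F)cc2)CN(C(=O)NCc2ccc(C#N)cc2)C[C@H]1c1ccc(C(O)(C(F)(F)F)C(F)(F)F)cc1`: 51%

In an ADME assay on microsomes from liver (Mus musculus) for metabolic stability, with a stated time of 10 min (on this read-out lower numbers stand for a less stable compound and higher numbers for a more stable compound), compound 2 stands higher of the two at 51%, well clear of compound 1 at 1%. Compound 3 `C[C@]1(c2ccc(F)cc2)CN(C(=O)C2CCN(S(C)(=O)=O)CC2)C[C@H]1c1ccc(C(O)(C(F)(F)F)C(F)(F)F)cc1` keeps the shared core but carries 1-(methylsulfonyl)piperidin-4-yl in place of (4-cyanobenzyl)amino on a carbonyl carbon. Among the measured compounds shown here, only one measured step bears on this change: a number 50 percentage points higher from compound 1 to compound 2 (beyond the scatter). That large step came from 4-cyanophenyl in place of pyridin-4-yl, within the part of the molecule now being replaced. It shows that this assay can respond strongly to changes there, but it says nothing about the entering group, which holds neither of those rings. No firm direction can therefore be expected, and the expected change is small but uncertain: a number 4 percentage points higher from compound 2 to compound 3 (within the scatter). For compound 3 the estimated value is 55%, with an expected range from 25% to 85%.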

Compound 3, percent of the compound remaining: 80%
For compound 3 the middle estimate is 25 percentage points below the measured one; the range from low to high includes it.
By their numbers in this assay, from the lowest: compound 1; then compound 2; then compound 3.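

In this assay, a high number at this carbonyl carbon does not depend on a benzylamino group: with 1-(methylsulfonyl)piperidin-4-yl there, a group with no aromatic ring and no hydrogen-bond donor, the result is a number 29 percentage points higher from compound 2 to compound 3 (beyond the scatter). The wider comparison gives a number 79 percentage points higher from compound 1 to compound 3 (beyond the scatter), so the replacement of the whole group reaches further than the change of aromatic ring alone did. Nothing available explains why the number rises with this change.

The entering group differs from the one it replaces in its ring, its sulfonyl group and its loss of the amide-type hydrogen, and these compounds cannot separate those features. An acetyl group in place of the methylsulfonyl group, or a free piperidine amine, would show how much of the step depends on the sulfonyl group.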